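Methyl on an Aromatic Nitrogen and Lipophilicity

The source may hold more compounds than are shown below. What is called first, only, known or untested is meant among the compounds shown, and "the series" means these compounds.

Compound 1, `Cc1[nH]c2ccc(Cl)cc2c(=O)c1Cc1ccccc1`: 2.79
Compound 2, `COc1ccc2c(=O)c(Cc3ccccc3)c(C)[nH]c2c1`: 2.52
Compound 3, `Cc1c(Cc2ccccc2)c(=O)c2cc(Cl)ccc2n1C`: 3.21

Of the compounds shown here, three have been measured in a physicochemical assay for lipophilicity, at pH 7.4; a higher number here means a more lipophilic compound, a lower number a more polar compound. Compound 3 differs from compound 1 in one place only: methyl in place of hydrogen on an aromatic nitrogen. In this assay that change gave a step of a number 0.42 log units higher from compound 1 to compound 3 (beyond the scatter). Compound 2 carries the lowest number of the three; its nearest neighbour is compound 1, whose value lies within the usual scatter of it, while compound 3 lies beyond the scatter of it. The cores of compound 1 and compound 2 differ in more than one place, and that difference is not broken down here.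

Compound 4 `COc1ccc2c(=O)c(Cc3ccccc3)c(C)n(C)c2c1` has not yet been measured. It stands to compound 2 as compound 3 stands to compound 1: methyl in place of hydrogen on an aromatic nitrogen. The surroundings of the place are the same, word for word, so this is the same change, made a second time on the core of compound 2.

For compound 4 in this assay a step from compound 2 of a number 0.42 log units higher from compound 2 to compound 4 (beyond the scatter) is expected, set beside the measured step of a number 0.42 log units higher from compound 1 to compound 3 (beyond the scatter), because the same change on the same kind of place gave a number 0.42 log units higher from compound 1 to compound 3 (beyond the scatter). That expectation rests on a single measured pair, compound 1 and compound 3, and on nothing else. Compound 4 is therefore estimated to come out at 2.94, expected to lie between 2.6 and 3.3.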

Compound 4, distribution coefficient: 3.24
The estimate for compound 4 lay 0.30 log units below the measured number; low and high end bracket the measured number.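

In this assay methyl in place of hydrogen on an aromatic nitrogen gave a number 0.72 log units higher from compound 2 to compound 4 (beyond the scatter) and, on the other core, a number 0.42 log units higher from compound 1 to compound 3 (beyond the scatter); in both pairs the number moved the same way and beyond the scatter. This shows that the direction of the step carried over from the core of compound 1 to the core of compound 2, while the printed size did not stay the same, and two single pairs cannot show whether that difference in size belongs to the cores or would recur on a third core. Nothing shown here bears on why the two steps differ in size.

The compounds shown leave open whether the step would hold for a group other than methyl on the aromatic nitrogen, such as ethyl or a longer chain, and whether it would hold on a core carrying an amine or a carboxylic acid instead of the chlorine or the methoxy group. On these data alone, all four compounds also carry the benzyl group, so the size of the step with another group in its place stays open as well.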